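Sulfonyl group exchange from compound 1 to compound 4

The compounds below may be only part of what the source reports. "The series", "measured", "known", "first", "only" and "open" are said of these compounds alone.

In an ADME assay on a cell-free system (plasma, Mus musculus) for metabolic stability, read by LC-MS, with a stated time of 60 min, tested at 1 uM (a lower number here means that less of the compound is left, a higher number that more of the compound is left), compound 1 (`CCn1c(CCCc2ccc(OC(C)(C)C(=O)NS(=O)(=O)c3ccccc3)cc2)nn(Cc2ccc(C(C)(C)C)cc2)c1=O`) gives 0.7% and stands at the low end of the three measured compounds, level within the scatter with compound 3 (`CCn1c(CCCc2ccc(OC(C)(C)C(=O)NS(=O)(=O)C3CCCC3)cc2)nn(Cc2ccc(C(C)(C)C)cc2)c1=O`), which gives 7% in the same read-out. Compound 2 (`CCn1c(CCCc2ccc(OC(C)(C)C(=O)NS(=O)(=O)c3ccc(C(F)(F)F)cc3)cc2)nn(Cc2ccc(C(C)(C)C)cc2)c1=O`) stands far off at 105% of compound left. Going by the values given here, compound 4 (`CCn1c(CCCc2ccc(OC(C)(C)C(=O)NS(=O)(=O)C3=CCOC=C3)cc2)nn(Cc2ccc(C(C)(C)C)cc2)c1=O`) differs from compound 1 in one place (a group of 6 heavy atoms (5 carbon, 1 oxygen; one six-membered non-aromatic ring with 1 hetero atom) in place of a group of 6 heavy atoms (6 carbon; one six-membered aromatic ring of carbon only), on a sulfonyl sulfur), and no measured step tests this ring. The closest evidence is the cyclopentyl exchange (a number 6.3 percentage points higher from compound 1 to compound 3 (within the scatter)). The large steps (a number 104.3 percentage points higher from compound 1 to compound 2 (beyond the scatter); a number 98 percentage points lower from compound 2 to compound 3 (beyond the scatter)) both turn on trifluoromethyl, which the new group lacks. In this assay no step beyond the scatter is therefore expected (a number 7.3 percentage points higher from compound 1 to compound 4 (within the scatter)). The estimate for compound 4 is 8% (0% to 40%).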

Compound 4, percent of the compound remaining: 86.5%
Compound 4: middle estimate off by 78.5 percentage points, on the low side, outside the stated range (above it).
By their numbers in this assay, from the lowest: compounds 1 and 3 (each within the scatter of the next); then compound 4; then compound 2.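

The sulfonyl sulfur position can give a high number in this assay without trifluoromethyl: a number 85.8 percentage points higher from compound 1 to compound 4 (beyond the scatter) and a number 79.5 percentage points higher from compound 3 to compound 4 (beyond the scatter) are both large. The new ring still falls short of the 4-(trifluoromethyl)phenyl group, as a number 18.5 percentage points lower from compound 2 to compound 4 (beyond the scatter) shows, though this step is modest. Nothing available explains the size of these steps.

As far as these compounds go, it remains open whether the ring oxygen or the double bonds carry the step, which a saturated six-membered ring with one oxygen could separate. Also open, from the compounds shown here alone, is whether chlorine or methoxy on the phenyl would act as trifluoromethyl does.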